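Sulfamoyl for Carbamoyl on the Aryl Sulfonamide Series

The source may report more compounds than this note shows. Statements on the series, on what has been measured and on what is new or still open speak of the compounds shown alone.

Of the compounds shown here, three sharing one piperidine carboxamide core have been measured. In a functional assay on MIA PaCa-2 cells (Homo sapiens) for inhibition, read by MTT assay, with a stated time of 3 days (on this read-out higher numbers stand for weaker inhibition and lower numbers for stronger inhibition), compound 1 `CCN(CC)S(=O)(=O)c1ccc(S(=O)(=O)N2CCC[C@@H](C(=O)NC3CN(C(=O)OC(C)(C)C)C3)C2)cc1` gives 100 nM, compound 3 `CCN(CC)S(=O)(=O)c1ccc(S(=O)(=O)N2CCC[C@@H](C(=O)N[C@H]3CCN(C(=O)OC(C)(C)C)C3)C2)cc1` gives 170 nM, and compound 2 `CCN(CC)C(=O)c1ccc(S(=O)(=O)N2CCC[C@@H](C(=O)N3CCN(c4nc(C(C)C)no4)CC3)C2)cc1` gives 70 nM. Among the compounds with values here, the only single-point step among them, a 1.7-fold higher number from compound 1 to compound 3 (0.23 log units; within the scatter), shows that widening the saturated ring on the amide nitrogen changes little. Compound 2 holds the lowest of the three numbers; its gap to compound 1 lies within the scatter, while its gap to compound 3 lies beyond it.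

Compound 4 `CCNS(=O)(=O)c1ccc(S(=O)(=O)N2CCC[C@@H](C(=O)N3CCN(c4nc(C(C)C)no4)CC3)C2)cc1` differs from compound 2 in one place: ethylsulfamoyl in place of diethylcarbamoyl on an aromatic carbon. Within the data shown here, no measured step bears directly on this exchange; the one step known concerns the amide side of the core, not the aryl substituent, and compounds 1 and 2 differ in two places at once, so their values show only that a diethylsulfamoyl-bearing analogue and a diethylcarbamoyl-bearing analogue both sit within the scatter of each other. With no direct guidance, the expected step from compound 2 to compound 4 in this assay is a 1.7-fold higher number from compound 2 to compound 4 (0.23 log units; within the scatter), at most a modest shift in either direction. Compound 4 is therefore estimated at 120 nM, in a range from 40 nM to 400 nM.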

Compound 4, half-maximal inhibitory concentration: 200 nM
Beside the measured number, compound 4's estimate is 1.7-fold (0.22 log units) below it; the range from low to high includes it.
By their numbers in this assay, from the lowest: compounds 2, 1, 3 and 4 (each within the scatter of the next, the first and the last beyond it).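

In this assay, the step of a 2.9-fold higher number from compound 2 to compound 4 (0.46 log units; beyond the scatter) is the only one shown at this position, on an aromatic carbon para to a large group. Within the data shown here, it lies beyond the scatter, whereas the one earlier step, on the amide side of the core, stayed within it, so this substituent can move the number measurably even though the step is modest, and of this pair the ethylsulfamoyl compound is the weaker inhibitor. The exchange changes several things at once, as ethylsulfamoyl brings sulfur into the group, carries a single ethyl rather than two and adds a hydrogen-bond donor, and no measurement here says which of these changes matters or why the number rises.

The compounds shown leave open whether the step follows from losing one ethyl or from replacing the carbonyl with the sulfonyl, a question that ethylcarbamoyl or diethylsulfamoyl on the core of compound 2 would separate. On these data alone, it also remains open how far the number would move with a shorter or longer chain on the sulfamoyl nitrogen, such as methyl or propyl.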